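A few compounds are considered here, and "the series" means these few. Any claim that something is new, unique, unknown or untested is made for them only; others in the source may bear on it.

Of the compounds shown here, two on the shared core have numbers so far in an ADME assay on MSTO-211H cells (Homo sapiens) for inhibition, read by trypan blue exclusion, with a stated time of 72 h; a higher number here means a weaker inhibitor of growth, a lower number a stronger inhibitor of growth. Compound 1 (`O=C(/C=C/c1ccccc1C(F)(F)F)c1ccccc1`) gives 8700 nM, and compound 2 (`O=C(/C=C/c1ccccc1)c1ccccc1C(F)(F)F`) gives 8500 nM. These two values lie within the scatter of each other, so compound 2 stands level with compound 1 and the pair cannot be ranked.

The next compound, compound 3 (`COc1ccccc1C(=O)/C=C/c1ccccc1`), differs from compound 2 at a single place: methoxy in place of trifluoromethyl on an aromatic carbon. This is methoxy in place of trifluoromethyl on an aromatic carbon, ortho to a large group. Among the compounds with values here, no measured pair yet shows what such an exchange does in this assay, so the expectation rests on thin evidence. Within the data shown here, the only guide is that compound 2, at 8500 nM, sits within the scatter of the one other compound measured. No shift beyond the scatter is expected in either direction, and the range is kept wide to reflect how little is known. The estimated change is a 1.1-fold lower number from compound 2 to compound 3 (0.05 log units; within the scatter). The expected value for compound 3 is 7500 nM, with an estimated range from 2800 nM to 20000 nM.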

Compound 3, concentration for 50% growth inhibition: 9500 nM
For compound 3 the middle estimate is 1.3-fold (0.10 log units) below the measured one; the range from low to high includes it.
By their numbers in this assay, from the lowest: compounds 2, 1 and 3 (each within the scatter of the next).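

In this assay, within the data shown here, putting methoxy in place of trifluoromethyl on an aromatic carbon, ortho to a large group, gives a 1.1-fold higher number from compound 2 to compound 3 (0.05 log units; within the scatter), and this is the first single-place step on the shared core that can be read. It shows that, at this position, the two groups leave compound 2 and compound 3 level, even though methoxy has fewer heavy atoms than trifluoromethyl and brings one hydrogen-bond acceptor where trifluoromethyl has none. No measurement at hand explains this level result, so it stands as an observation for this one pair.

What the compounds shown leave open is whether this level result holds for other kinds of group at the same position, such as an amine, a carboxylic acid or a longer chain like ethoxy, or whether one of them would give a step beyond the scatter. From the compounds shown here alone, it also remains open whether methoxy or trifluoromethyl on a different aromatic carbon of the shared core would leave the number just as level.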